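The source may report more compounds than this note shows. Statements on the series, on what has been measured and on what is new or still open speak of the compounds shown alone.

In an ADME assay on CHO cells (Cricetulus griseus) for inhibition, read by MTT assay (on this read-out higher numbers stand for weaker inhibition and lower numbers for stronger inhibition), compound 1 (`CCNCc1cc(C)cc(Nc2nc3ccccc3n2Cc2ccc(C(F)(F)F)cc2)c1O`) gives 18800 nM and compound 2 (`CCNCc1cc(Cl)cc(Nc2nc3ccccc3n2Cc2ccc(C(F)(F)F)cc2)c1O`) gives 33800 nM as its value, so these two numbers lie within the scatter of each other. Compound 3 (`CCN(CC)Cc1ccc(C)c(Nc2nc3ccccc3[nH]2)c1O`) has > 50000 nM as its entry, which is a limit of the assay and not a number. Compound 1 therefore has only compound 2 as a numerical neighbour.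

Compound 4 (`Cc1cc(CNC(C)(C)C)c(O)c(Nc2nc3ccccc3n2Cc2ccc(C(F)(F)F)cc2)c1`) keeps the core of compound 1 and makes a single change, tert-butyl in place of ethyl on an amine nitrogen. For the measured compounds named here, no measured step touches that amine nitrogen. Going by the values given here, the only step available, (a 1.8-fold higher number from compound 1 to compound 2 (0.25 log units; within the scatter)), is chloro in place of methyl on an aromatic carbon and stays within the scatter, so it offers no direct guide. Going by these compounds, no step beyond the scatter is expected in this assay and the direction remains open, with (a 1.1-fold higher number from compound 1 to compound 4 (0.03 log units; within the scatter)) as the expected step. The estimate for compound 4 is 20000 nM as a central value, with 8000 nM to 45000 nM as the expected range.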

Compound 4, half-maximal inhibitory concentration in the CHO assay: 30000 nM
Estimate against measurement, compound 4: 1.5-fold (0.18 log units) below; the range from low to high includes it.
By their numbers in the CHO assay, from the lowest: compounds 1, 4 and 2 (each within the scatter of the next). At a limit, above all of these: compound 3.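

This is the first change shown on the amine nitrogen: in the CHO assay, tert-butyl in place of ethyl gives (a 1.6-fold higher number from compound 1 to compound 4 (0.20 log units; within the scatter)), so the two compounds cannot be told apart even though the group grows from 2 heavy atoms to 4. In a physicochemical assay for solubility, read by HPLC, measured as kinetic solubility, with a stated time of 24 h, at pH 6.5 (on this read-out higher numbers stand for higher solubility and lower numbers for lower solubility), compound 1 gives 35000 nM and compound 4 gives 50000 nM as its value, and the same change gives (a 1.4-fold higher number from compound 1 to compound 4 (0.15 log units; within the scatter)), so this read-out cannot separate them either. In the CHO assay, compound 3 has > 50000 nM as its entry, which is a limit of the assay and not a number: (the limit of > 50000 nM in the CHO assay, at which 1 of the 4 values shown sits).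

Among compounds that differ only at this place, ethyl and tert-butyl are the only groups shown on the amine nitrogen, so the effect of a longer chain or a chain ending in a carboxylic acid remains open. Going by these compounds, whether any group here can move either read-out beyond the scatter also remains open.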